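This account rests on a few compounds, and the source may have more. Where it says the series, first, only, none or still open, it means among the compounds named here.

Compound 1 `CCOc1ccc(NC(=O)Nc2cccc(CNc3nccnc3Cl)c2)cc1`, compound 2 `O=C(Nc1cccc(CNc2nccnc2Cl)c1)NC1CCCCC1` and compound 3 `CN(C)c1ccc(NC(=O)Nc2cccc(CNc3nccnc3Cl)c2)cc1` share one core and differ only in the group on the amide-type nitrogen of the urea. In a functional assay on HepG2 cells (Homo sapiens) for antiproliferative activity, read by MTT assay, with a stated time of 48 h (a higher number here means a weaker inhibitor, a lower number a stronger inhibitor), compound 1 gives 7050 nM. Compound 2 reaches only the limit of this assay, > 40000 nM. Compound 3 likewise reaches only the limit, > 40000 nM. For the measured compounds named here, compound 1 thus holds the only number in the set, the other two values being (the limit of > 40000 nM in this assay, at which 2 of the 3 values shown sit).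

The step of an at least 5.6-fold higher number from compound 1 to compound 2 (0.75 log units; beyond the scatter) follows from putting cyclohexyl in place of 4-ethoxyphenyl, and the step of an at least 5.6-fold higher number from compound 1 to compound 3 (0.75 log units; beyond the scatter) from dimethylamino in place of ethoxy; both steps move at least modestly toward weaker inhibition. The step from compound 2 to compound 3 cannot be read, since both sit at the limit.

Compound 4 `CCc1ccccc1NC(=O)Nc1cccc(CNc2nccnc2Cl)c1` is the next member, differing from compound 1 by 2-ethylphenyl in place of 4-ethoxyphenyl on an amide-type nitrogen. Both measured departures from compound 1 raised the number, and compound 4 keeps an aromatic ring but loses the ethoxy acceptor, so the expected step is a 2.6-fold higher number from compound 1 to compound 4 (0.41 log units; beyond the scatter). Compound 4 is estimated at 18000 nM, within 6000 nM to 40000 nM.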

Compound 4, half-maximal inhibitory concentration: 7860 nM
Beside the measured number, compound 4's estimate is 2.3-fold (0.36 log units) above it; measured number inside the range.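

The ethoxy oxygen proves dispensable at this position: putting 2-ethylphenyl in place of 4-ethoxyphenyl on the amide-type nitrogen gives a 1.1-fold higher number from compound 1 to compound 4 (0.05 log units; within the scatter) in this assay, so the hydrogen-bond acceptor that leaves with the 4-ethoxyphenyl group is not needed to keep this level of activity. The same group gives an at least 5.0-fold lower number from compound 3 to compound 4 (0.70 log units; beyond the scatter) and an at least 5.0-fold lower number from compound 2 to compound 4 (0.70 log units; beyond the scatter), so activity here is not tied to one particular aromatic substituent, although compound 3 goes against any rule that an aromatic ring alone is enough. Those two steps rest on limits and not on numbers: the limit of > 40000 nM in this assay, at which 2 of the 4 values shown sit.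

Going by these compounds, whether the ethyl group matters at all remains open, as an unsubstituted phenyl would show. A 4-ethylphenyl or a 2-ethoxyphenyl group would separate the effect of the substituent from that of its place on the ring.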